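This account rests on a few compounds, and the source may have more. Where it says the series, first, only, none or still open, it means among the compounds named here.

Compound 1, `COc1ccc(NC(=O)C(=O)c2cn(CC3CCCO3)c3ccccc23)cn1`: 31 nM
Compound 2, `COc1ncc(NC(=O)C(=O)c2cn(C(C)C)c3ccccc23)cn1`: 171 nM

Both compounds were tested in a functional assay on FaDu cells (Homo sapiens) for cytotoxicity, read by MTT assay, with a stated time of 72 h; a higher number here means that more compound is tolerated, a lower number that less compound is tolerated. Compound 1 has the lower of the two numbers, so fewer of it is tolerated by the cells; in this assay compound 1 gives 31 nM. For the measured compounds named here, compound 2 differs from it in more than one place, so no single step links the two; its value of 171 nM simply lies beyond the scatter above that of compound 1.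

Compound 3, `COc1ccc(NC(=O)C(=O)c2cn(C3CCCC3)c3ccccc23)cn1`, has not yet been measured. It differs from compound 1 in a single place: cyclopentyl in place of (oxolan-2-yl)methyl on an aromatic nitrogen. Going by the values given here, no measured pair shows the effect of this change on its own, and compound 2, which carries a different small group on the same nitrogen, also carries a different ring elsewhere, so it cannot settle the question. The cyclopentyl group is close in size to the group it replaces but lacks the oxygen. The expected step from compound 1 to compound 3 is a 1.6-fold higher number from compound 1 to compound 3 (0.21 log units; within the scatter), a small shift toward a higher number, not clearly beyond the scatter. Compound 3 is therefore estimated at 50 nM, within a range of 15 nM to 170 nM.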

Compound 3, concentration lethal to 50% of the cells: 370 nM
The estimate for compound 3 lay 7.4-fold (0.87 log units) below the measured number; the whole stated range lies below it.
By their numbers in this assay, from the lowest: compound 1; then compound 2; then compound 3.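

In this assay, the group on the aromatic nitrogen proves to matter a great deal: cyclopentyl in place of (oxolan-2-yl)methyl gives a 12-fold higher number from compound 1 to compound 3 (1.08 log units; beyond the scatter), so the cells tolerate much more of compound 3. This position is therefore sensitive even to a change between two groups that both carry a five-membered non-aromatic ring, the one with a ring oxygen and a hydrogen-bond acceptor, the other of carbon only and with no acceptor. Nothing measured here shows why the step is so large, and no outside evidence bears on it.

The step changes more than one thing at once, since the oxygen is lost and the ring also goes from hanging on a methyl link to sitting directly on the nitrogen, so the two changes cannot be told apart. A cyclopentylmethyl group would keep the link and lose only the oxygen, while an open chain such as 2-methoxyethyl would keep an oxygen without the ring, and the compounds shown include neither.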